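A few compounds are considered here, and "the series" means these few. Any claim that something is new, unique, unknown or untested is made for them only; others in the source may bear on it.

Going by the values given here, in a functional assay on HL-60 cells (Homo sapiens) for cytotoxicity, read by MTT assay, with a stated time of 96 h (on this read-out lower numbers stand for stronger inhibition and higher numbers for weaker inhibition), compound 2 (`CC[C@H](N)C(=O)N[C@@H]1C(=O)N2[C@@H](CC[C@@H]1CCN)CC[C@H]2C(=O)NC(c1ccccc1)c1ccccc1`) gives 25000 nM and stands lowest of the two numbers so far, while compound 1 (`CC[C@H](NC)C(=O)N[C@@H]1C(=O)N2[C@@H](CC[C@@H]1CN)CC[C@H]2C(=O)NC(c1ccccc1)c1ccccc1`) gives 51800 nM as the higher number, a gap beyond the scatter. Compound 3 (`CC[C@H](NC)C(=O)N[C@@H]1C(=O)N2[C@@H](CC[C@@H]1CCN)CC[C@H]2C(=O)NC(c1ccccc1)c1ccccc1`) differs from compound 2 by methyl in place of hydrogen on an amine nitrogen. Among the compounds with values here, no measured pair shows this change alone, so in this assay no step beyond the scatter is expected. The expected size is a 1.1-fold lower number from compound 2 to compound 3 (0.06 log units; within the scatter) and so stays within the scatter. For compound 3 the estimated value is 22000 nM (expected range 8000 nM to 60000 nM).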

Compound 3, half-maximal inhibitory concentration: 31000 nM
Compound 3: the middle estimate sits 1.4-fold (0.15 log units) below what was measured, and the stated range covers the measured number.
By their numbers in this assay, from the lowest: compounds 2, 3 and 1 (each within the scatter of the next, the first and the last beyond it).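

In this assay, methyl in place of hydrogen on the amine nitrogen gives a 1.2-fold higher number from compound 2 to compound 3 (0.09 log units; within the scatter) on its own, so this addition does not separate the two compounds. Aminomethyl in place of amino on a saturated chain carbon bound to a saturated ring carbon gives a 1.7-fold lower number from compound 1 to compound 3 (0.22 log units; within the scatter) and so does not separate its pair either. No measurement at hand offers a reason for these results. Still open, from the compounds shown here alone, is whether ethyl on that amine nitrogen, or a longer chain in place of aminomethyl, would give a step beyond the scatter.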